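Notes on the amine ring swap from compound 3 to compound 4

A few compounds are considered here, and "the series" means these few. Any claim that something is new, unique, unknown or untested is made for them only; others in the source may bear on it.

Compound 1 `COc1cccc(/C=C/C(=O)c2sc(Nc3ccccc3)nc2C)c1`, compound 2 `Cc1nc(Nc2ccccc2)sc1C(=O)/C=C/c1ccc(Cl)cc1` and compound 3 `COc1cc(/C=C/C(=O)c2sc(Nc3ccc(Cl)c(Cl)c3)nc2C)cc(OC)c1OC` have each been run in a functional assay on NCI-H460 cells (Homo sapiens) for cytotoxicity, read by MTT assay; a higher number here means a weaker inhibitor, a lower number a stronger inhibitor. In this assay compound 1 reaches only a limit of the assay, > 25000 nM. Compound 2 likewise gives only a limit, > 25000 nM. Compound 3 also stops at a limit, > 25000 nM. the limit of > 25000 nM in this assay, at which 3 of the 3 values shown sit, states where all three stand. Among the measured compounds shown here, the single one-site step among the measured compounds, a step that the two limits leave unreadable from compound 1 to compound 2, cannot be read in size, as both of its ends are limits.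

Compound 4 `COc1cc(/C=C/C(=O)c2sc(Nc3ccccc3C)nc2C)cc(OC)c1OC` differs from compound 3 by 2-methylphenyl in place of 3,4-dichlorophenyl on a nitrogen on an aromatic ring. For the measured compounds named here, no measured step touches the ring carried on that nitrogen: the one measured step lies on the chain end, and its two ends are limits in any case. Compound 3 itself is a limit, so no step size can be taken from the numbers available. The expectation for compound 4 can rest only on the fact that every measured member of the series has so far failed to give a number in this assay. Compound 4 is therefore expected to remain in the same region, estimated at 35000 nM, with a range of 10000 nM to 120000 nM. The implied step, a step that the limit leaves unreadable from compound 3 to compound 4, is expected to stay within the scatter.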

Compound 4, half-maximal inhibitory concentration: 6320 nM
Estimate against measurement, compound 4: 5.5-fold (0.74 log units) above; the whole stated range lies above it.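

Swapping 3,4-dichlorophenyl for 2-methylphenyl on a nitrogen on an aromatic ring gives, in this assay, an at least 3.9-fold lower number from compound 3 to compound 4 (0.59 log units; beyond the scatter), and compound 4 is the first compound in the series to give a number rather than a limit. The value of compound 3, > 25000 nM, is a limit of the assay and not a number, and the step gives only a minimum size. The ring on this nitrogen is therefore a place where the read-out can change, which the earlier compounds could not show, as their one step on the chain end cannot be read between two limits, and most of the series still stands at the edge of the assay: the limit of > 25000 nM in this assay, at which 3 of the 4 values shown sit.

The compounds shown do not separate any gain from the 2-methylphenyl group from the loss of the 3,4-dichlorophenyl group, and they do not show whether the step carries over to another group on the chain end. From the compounds shown here alone, how a cyclohexyl ring or a pyridine ring on the same nitrogen would read in this assay also remains open.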